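Chloro to Bromo on the Aryl Ring of Compound 2

The source may report more compounds than this note shows. Statements on the series, on what has been measured and on what is new or still open speak of the compounds shown alone.

The study concerns two measured compounds sharing one core. Compound 1 `Cc1ccc2c(Cc3nn4c(C=O)c(-c5ccc(Br)cc5)nc4s3)coc2c1` and compound 2 `Cc1ccc2c(Cc3nn4c(CO)c(-c5ccc(Cl)cc5)nc4s3)coc2c1` were tested in a functional assay on the whole organism (strain Wistar albino) for inhibition, with Rattus norvegicus as the target, read by paw edema, with a stated time of 1 h, at a dose of 100 mg/kg by the oral route; on this read-out higher numbers stand for more inhibition at the one dose given (going by the name of the read-out) and lower numbers for less inhibition. There compound 1 gives 12.4%, and compound 2 gives 14.5%. Compound 2 thus stands at the top end of the two numbers shown, but compound 1 lies within the usual scatter of it, so the two are not separated by this read-out. Among the measured compounds shown here, no pair of compounds differing in a single place has been measured, so no single step is known.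

Compound 3 `Cc1ccc2c(Cc3nn4c(CO)c(-c5ccc(Br)cc5)nc4s3)coc2c1` has not yet been measured. It differs from compound 2 in one place: bromo in place of chloro on an aromatic carbon. For the measured compounds named here, no measured pair shows what such an exchange does here, so compound 3 is expected to stay near compound 2, with a step of a number 1.5 percentage points lower from compound 2 to compound 3 (within the scatter) that is estimated to lie within the scatter. Compound 3 is therefore expected to give about 13%, in a range from 5% to 22%.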

Compound 3, a percentage reported as inhibition, in the whole organism at one dose (the size of the read-out at that dose, not a potency): 7.2%
Compound 3: the middle estimate sits 5.8 percentage points above what was measured, and the stated range covers the measured number.
By their numbers in this assay, from the lowest: compounds 3, 1 and 2 (each within the scatter of the next).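

These are the first single-place readings for the compounds shown. In this assay, bromo in place of chloro on the aromatic carbon gives a number 7.3 percentage points lower from compound 2 to compound 3 (within the scatter), so the 4-chlorophenyl to 4-bromophenyl exchange does not separate the two compounds on this read-out. Hydroxymethyl in place of formyl on an aromatic carbon likewise gives a number 5.2 percentage points lower from compound 1 to compound 3 (within the scatter), so neither position shows a step beyond the scatter, and no measurement offered here accounts for these results.

Going by these compounds, what remains open is whether a carboxylic acid or an amine in place of the hydroxymethyl would give a step beyond the scatter. On these data alone, it is equally open whether fluoro, methoxy or a hydrogen in place of the bromo on the aromatic ring would do so.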